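Replacing butylamino with piperidin-1-yl on a carbonyl carbon

A few compounds are considered here, and "the series" means these few. Any claim that something is new, unique, unknown or untested is made for them only; others in the source may bear on it.

- Compound 1 `CCCCc1oc2ccccc2c1C(=O)c1ccc(OCC(=O)N2CCCCC2)cc1` gives > 50000 nM (a limit)
- Compound 2 `CCCCc1oc2ccccc2c1C(=O)c1ccc(OCC(=O)Nc2ccccc2)cc1` gives > 50000 nM (a limit)
- Compound 3 `CCCCNC(=O)CCCOc1ccc(C(=O)c2c(CCCC)oc3ccccc23)cc1` gives 38100 nM (a number)

In a functional assay on MDA-MB-231 cells (Homo sapiens) for antiproliferative activity, read by MTT assay, with a stated time of 24 h (on this read-out lower numbers stand for stronger inhibition and higher numbers for weaker inhibition), compound 3 is the only one of the three with a number (38100 nM). Compound 1 and compound 2 give no number (the limit of > 50000 nM in this assay, at which 2 of the 3 values shown sit).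

Compound 4 `CCCCc1oc2ccccc2c1C(=O)c1ccc(OCCCC(=O)N2CCCCC2)cc1` has not been measured. It differs from compound 3 by piperidin-1-yl in place of butylamino on a carbonyl carbon.

Among the measured compounds shown here, no measured step makes this exchange alone. The nearest steps change the group on the saturated chain carbon (an at least 1.3-fold lower number from compound 1 to compound 3 (0.11 log units; that floor lies within the scatter)) and (an at least 1.3-fold lower number from compound 2 to compound 3 (0.11 log units; that floor lies within the scatter)). Compound 1 carries the same piperidin-1-yl on a carbonyl carbon, but its step to anilino gives no size (a step that the two limits leave unreadable from compound 1 to compound 2).

The expectation therefore rests on compound 3 (38100 nM) and on those two small floors. In this assay the expected step is a slightly higher number that stays within the scatter (a 1.2-fold higher number from compound 3 to compound 4 (0.07 log units; within the scatter)). A report of only a limit would not be surprising. For compound 4 the estimate is 45000 nM and the expected range runs between two ends (20000 nM and 100000 nM).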

Compound 4, half-maximal inhibitory concentration: 36000 nM
Estimate against measurement, compound 4: 1.3-fold (0.10 log units) above; low and high end bracket the measured number.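

In this assay, among the compounds shown here, this is the first readable exchange at this carbonyl carbon: piperidin-1-yl in place of butylamino gives a 1.1-fold lower number from compound 3 to compound 4 (0.02 log units; within the scatter), so neither closing the ring nor losing the amide hydrogen of compound 3 separates the two compounds. With piperidin-1-yl kept on the carbonyl carbon and only the saturated chain changed, the step is an at least 1.3-fold lower number from compound 1 to compound 4 (0.14 log units; that floor lies within the scatter), and the step that also replaces anilino is an at least 1.3-fold lower number from compound 2 to compound 4 (0.14 log units; that floor lies within the scatter), so neither floor establishes a real difference. Compound 1 and compound 2 give only a limit of the assay, not a number: the limit of > 50000 nM in this assay, at which 2 of the 4 values shown sit.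

The compounds shown leave open whether any group on this carbonyl carbon, such as morpholin-4-yl or the hydroxyl of a free carboxylic acid, would produce a step beyond the scatter. They also leave open what anilino does on the 2-carbonylethyl chain, and whether a longer chain would change the number in this assay.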